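Moving the nitro group on the triazole-borne aryl

The source may hold more compounds than are shown below. What is called first, only, known or untested is meant among the compounds shown, and "the series" means these compounds.

Three compounds share a core whose triazole carries an aryl group on an aromatic nitrogen. Compound 1 `C/C(=C\CC/C(C)=C/CC[C@@H]1[C@@]2(C)CCC(=O)C(C)(C)[C@H]2CC[C@@]1(C)O)CC/C=C(\C)C(=O)OCc1cn(-c2cccc(O)c2)nn1` bears a 3-hydroxyphenyl there, and in a functional assay on DU-145 cells (Homo sapiens) for antiproliferative activity, read by MTT assay, with a stated time of 48 h (a higher number here means a weaker inhibitor, a lower number a stronger inhibitor), compound 1 gives 28400 nM. Compound 2 `C/C(=C\CC/C(C)=C/CC[C@@H]1[C@@]2(C)CCC(=O)C(C)(C)[C@H]2CC[C@@]1(C)O)CC/C=C(\C)C(=O)OCc1cn(-c2ccc(F)c(Cl)c2)nn1` bears a 3-chloro-4-fluorophenyl. In this assay compound 2 reaches only a limit, > 150000 nM. Compound 3 `C/C(=C\CC/C(C)=C/CC[C@@H]1[C@@]2(C)CCC(=O)C(C)(C)[C@H]2CC[C@@]1(C)O)CC/C=C(\C)C(=O)OCc1cn(-c2ccccc2[N+](=O)[O-])nn1` bears a 2-nitrophenyl. In this assay compound 3 likewise reaches only a limit, > 150000 nM. Compound 3 thus stands at the limit of > 150000 nM in this assay, at which 2 of the 3 values shown sit. The step of an at least 5.2-fold higher number from compound 1 to compound 2 (0.72 log units; beyond the scatter) and the step of an at least 5.2-fold higher number from compound 1 to compound 3 (0.72 log units; beyond the scatter) point the same way, while the step that the two limits leave unreadable from compound 2 to compound 3 cannot be read. Compound 4 `C/C(=C\CC/C(C)=C/CC[C@@H]1[C@@]2(C)CCC(=O)C(C)(C)[C@H]2CC[C@@]1(C)O)CC/C=C(\C)C(=O)OCc1cn(-c2cccc([N+](=O)[O-])c2)nn1` differs from compound 3 by 3-nitrophenyl in place of 2-nitrophenyl on an aromatic nitrogen. For the measured compounds named here, no measured step touches where the nitro group sits on this phenyl; the two steps reaching the limit show only that replacing the 3-hydroxyphenyl weakens inhibition. Compound 4 is therefore expected to stay near the limit, with a step of a number no higher from compound 3 to compound 4 (the limit leaves the size open) expected to lie within the scatter. The estimate for compound 4 is 150000 nM, between 40000 nM and 400000 nM.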

Compound 4, half-maximal inhibitory concentration: > 150000 nM
Compound 4 was reported as a limit (the forecaster's own chance of this, stated with the estimate: 60%); the middle value sits exactly at the limit.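

Moving the nitro group from the 2-nitrophenyl to the 3-nitrophenyl leaves this assay without a readable answer, as compound 4, like compound 3, gives a limit and not a number. For the compounds shown here, the one readable step, nitro in place of hydroxy on an aromatic carbon, is an at least 5.2-fold higher number from compound 1 to compound 4 (0.72 log units; beyond the scatter); unlike the earlier steps from compound 1, it exchanges only a single group on the phenyl. The steps among compound 2, compound 3 and compound 4 cannot be read, and compound 1 remains the only one of these compounds with a value that is not a limit: the limit of > 150000 nM in this assay, at which 3 of the 4 values shown sit.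

As far as these compounds go, whether the place of the nitro group matters at all therefore stays open. So does what a 2-hydroxyphenyl, or an amine or a methoxy group in place of the hydroxy, would give.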